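Adding a Methyl to the Methoxy Group of Compound 3

The compounds below may be only part of what the source reports. "The series", "measured", "known", "first", "only" and "open" are said of these compounds alone.

Compound 1, `Cc1cc(C(=O)N2CCCCc3ccccc32)ccc1CNC(=O)NCC(=O)OC(C)C`, gives 140 nM in a functional assay on HEK293 cells for agonist activity at Vasopressin V2 receptor (Homo sapiens), read by a luciferase reporter and cAMP accumulation; on this read-out higher numbers stand for an effect only at larger amounts of compound and lower numbers for an effect already at smaller amounts.
Compound 2, `Cc1cc(C(=O)N2CCCCc3ccccc32)ccc1CNC(=O)NCC(=O)OC(C)(C)C`, gives 120 nM in this assay.
Compound 3, `CO[C@@H]1C[C@@H](C(=O)N(C)C)N(C(=O)NCc2ccc(C(=O)N3CCCCc4ccccc43)cc2C)C1`, gives 4.7 nM in this assay.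

Compound 3 has a different core from compound 1, namely (2-(dimethylcarbamoyl)-4-methoxypyrrolidin-1-yl in place of ((isopropoxycarbonyl)methyl)amino on a carbonyl carbon), and that change made a step of a 30-fold lower number from compound 1 to compound 3 (1.47 log units; beyond the scatter). Compound 1 and compound 2 differ by methyl in place of hydrogen on a saturated chain carbon bound to an oxygen next to a carbonyl group and two saturated chain carbons, a change that occurs twice among these compounds and that made a step of a 1.2-fold lower number from compound 1 to compound 2 (0.07 log units; within the scatter).

Compound 4, `CCO[C@@H]1C[C@@H](C(=O)N(C)C)N(C(=O)NCc2ccc(C(=O)N3CCCCc4ccccc43)cc2C)C1`, is not yet measured. It differs from compound 3 by methyl in place of hydrogen on a saturated chain carbon bound to an oxygen on a saturated carbon. Going by the values given here, this is the same kind of change as the one from compound 1 to compound 2, though the place differs: here the carbon is bound to an oxygen on a saturated carbon, whereas in compound 1 it is bound to an oxygen next to a carbonyl group and two saturated chain carbons. A small step is expected, a 1.1-fold higher number from compound 3 to compound 4 (0.03 log units; within the scatter), because a 1.2-fold lower number from compound 1 to compound 2 (0.07 log units; within the scatter) was within the scatter. Compound 4 is therefore estimated at 5 nM, likely between 2 nM and 12 nM.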

Compound 4, half-maximal effective concentration: 4.3 nM
Compound 4: middle estimate off by 1.2-fold (0.07 log units), on the high side; the measured number falls inside the stated range.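

Replacing methoxy with ethoxy gave a 1.1-fold lower number from compound 3 to compound 4 (0.04 log units; within the scatter) in this assay. Set beside the earlier step, the same added methyl behaves alike on the two cores: the same change on two cores in this assay, a 1.2-fold lower number (0.07 log units; within the scatter) from compound 1 to compound 2 and a 1.1-fold lower number (0.04 log units; within the scatter) from compound 3 to compound 4, 1.1-fold (0.03 log units) apart, within the scatter of two such steps This shows only that, at these two places on these two cores, the added methyl leaves the number unchanged within the scatter; it does not show that the change would do the same on any other core or at any other place.

The compounds shown leave open whether a longer chain such as propoxy, or a hydroxyl group, in place of the methoxy would also leave the number unchanged. They also leave open what an amine or a carboxylic acid in place of the dimethylcarbamoyl group would do.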